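Methoxy to Methoxymethyl on Two Related Cores

A few compounds are considered here, and "the series" means these few. Any claim that something is new, unique, unknown or untested is made for them only; others in the source may bear on it.

Compound 1 `COCCNC(=C\C(=O)/C=C/c1ccc(O)cc1)/C=C/c1ccc(O)cc1` is tested in a functional assay on Caco-2 cells (Homo sapiens) for cytotoxicity, read by MTT assay, with a stated time of 48 h; on this read-out higher numbers stand for weaker inhibition and lower numbers for stronger inhibition; in that assay compound 1 gives 28000 nM. Compound 3 `COCCCNC(=C\C(=O)/C=C/c1ccc(O)cc1)/C=C/c1ccc(O)cc1` differs from it by the change (methoxymethyl in place of methoxy on a saturated chain carbon, two bonds along the chain from an amine nitrogen), and in this assay compound 3 gives 24000 nM. The resulting step, a 1.2-fold lower number from compound 1 to compound 3 (0.07 log units; within the scatter), is small and lies within the usual scatter, so the two values are treated as indistinguishable.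

The second core belongs to compound 2 `COCCNC(=C\C(=O)/C=C/c1ccc(O)c(OC)c1)/C=C/c1ccc(O)c(OC)c1`; how it differs from the core of compound 1 is not broken down here. In this assay compound 2 reports only a limit of the assay, > 100000 nM, and not a number, as recorded by the limit of > 100000 nM in this assay, at which 1 of the 3 values shown sits.

Compound 4 `COCCCNC(=C\C(=O)/C=C/c1ccc(O)c(OC)c1)/C=C/c1ccc(O)c(OC)c1` stands to compound 2 as compound 3 stands to compound 1: the same change, (methoxymethyl in place of methoxy on a saturated chain carbon, two bonds along the chain from an amine nitrogen), which occurs twice among these compounds. Because the measured step of a 1.2-fold lower number from compound 1 to compound 3 (0.07 log units; within the scatter) did not move the read-out beyond the scatter, the step from compound 2 to compound 4 is expected to be equally small, a step that the limit leaves unreadable from compound 2 to compound 4. Compound 4 is accordingly estimated at 120000 nM, most likely between 50000 nM and 300000 nM, with a real chance that the assay again returns only a limit.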

Compound 4, half-maximal inhibitory concentration: 49100 nM
For compound 4 the middle estimate is 2.4-fold (0.39 log units) above the measured one, and the stated range ends above it.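

In this assay, the change from 2-methoxyethyl to 3-methoxypropyl on the amine nitrogen gives an at least 2.0-fold lower number from compound 2 to compound 4 (0.30 log units; that floor lies within the scatter), a floor and not a full measure of the step. Set beside the step on the core of compound 1, this reading neither confirms nor rules out that the change carries over unchanged from one core to the other: the same change on two cores in this assay, a 1.2-fold lower number (0.07 log units; within the scatter) from compound 1 to compound 3 and an at least 2.0-fold lower number (0.30 log units; that floor lies within the scatter) from compound 2 to compound 4; the limit leaves it open whether they differ. As far as these compounds go, compound 2 has only a limit of the assay, so the true size of the step on its core stays unknown, and the series cannot show whether that step is larger than the one on the core of compound 1: the limit of > 100000 nM in this assay, at which 1 of the 4 values shown sits.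

The compounds shown leave open how a longer chain such as 4-methoxybutyl, or an amine or a hydroxyl group in place of the chain's methoxy, would read on either core. They also leave open how this change would read on a further core where both partners give numbers.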